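Adding a methyl to a benzylidene cyclohexanone

The source may report more compounds than this note shows. Statements on the series, on what has been measured and on what is new or still open speak of the compounds shown alone.

Compound 1, `COc1ccc(/C=C2\CCC3=CC(=O)CCC3(C)C2=O)cc1`, is a ring-fused ketone carrying a methoxyphenyl group. In a functional assay on B16 cells (Mus musculus) for inhibition, with a stated time of 3 days (on this read-out higher numbers stand for weaker inhibition and lower numbers for stronger inhibition), compound 1 gives 6000 nM. Compound 2, `CC1CCC/C(=C\c2ccccc2)C1=O`, is a much smaller molecule: a single ketone ring bearing a methyl and a plain benzylidene group. In this assay compound 2 reaches only the limit of the measurement, reported as > 30000 nM. Because of the limit of > 30000 nM in this assay, at which 1 of the 2 values shown sits, the value of compound 2 is not a number but the edge of what this assay can report, so compound 2 stands at the weak end of the two results shown, while compound 1 has a real number.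

Compound 3, `Cc1ccc(/C=C2\CCCC(C)C2=O)cc1`, keeps the core of compound 2 and differs from it only on the aromatic ring: methyl in place of hydrogen on an aromatic carbon. Going by the values given here, no measured pair in this set shows what such a change does in this assay. With a single methyl group the expected step from compound 2 to compound 3, a step that the limit leaves unreadable from compound 2 to compound 3, is therefore small, with no direction claimed beyond the scatter. Compound 3 is accordingly expected to give about 35000 nM in this assay, within a range from 10000 nM to 120000 nM, most likely again reported only as a limit.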

Compound 3, half-maximal inhibitory concentration: > 30000 nM
Compound 3 gave a limit, no number (the forecaster's own chance of this, stated with the estimate: 70%); the middle value does not contradict the limit.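

In this assay, compound 2 and compound 3 each end at a limit and not at a number, so no step can be read between them: the limit of > 30000 nM in this assay, at which 2 of the 3 values shown sit.

The compounds shown leave open whether methyl in place of hydrogen on an aromatic carbon changes inhibition at all on this shared core.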